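A few compounds are considered here, and "the series" means these few. Any claim that something is new, unique, unknown or untested is made for them only; others in the source may bear on it.

Among the measured compounds shown here, in an assay on HEK293 cells for inhibition of Voltage-dependent T-type calcium channel subunit alpha-1G (Homo sapiens), read by patch clamp (on this read-out lower numbers stand for stronger inhibition and higher numbers for weaker inhibition), compound 3 `CCCc1nc(-c2ccccc2)c(CNCCN2CCN(c3ccc(OC)cc3)CC2)o1` gives 9200 nM, the highest of the three numbers measured so far. Compound 1 `CCCc1nc(-c2ccccc2)c(CNCCN2CCN(c3ccccc3Cl)CC2)o1` gives 4370 nM, and compound 2 `CCCc1nc(-c2ccccc2)c(CNCCN2CCN(c3ccccc3C(F)(F)F)CC2)o1` gives 2100 nM. The steps of a 2.1-fold higher number from compound 1 to compound 3 (0.32 log units; beyond the scatter) and a 4.4-fold higher number from compound 2 to compound 3 (0.64 log units; beyond the scatter) both leave compound 3 as the weakest of the three. Compound 4 `CCCc1nc(-c2ccccc2)c(CNCCN2CCN(c3ccc(C(F)(F)F)cc3)CC2)o1` differs from compound 3 by trifluoromethyl in place of methoxy on an aromatic carbon. The step that bears most on this is a 2.1-fold lower number from compound 1 to compound 2 (0.32 log units; beyond the scatter), where a trifluoromethyl also entered, though in exchange for chloro rather than methoxy. A step of comparable size, toward a lower number in this assay, is therefore expected for compound 4, and the estimated step is a 2.1-fold lower number from compound 3 to compound 4 (0.32 log units; beyond the scatter). Compound 4 is expected to give about 4400 nM, with a likely range from 1500 nM to 12000 nM.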

Compound 4, half-maximal inhibitory concentration: 1300 nM
Estimate against measurement, compound 4: 3.4-fold (0.53 log units) above; measured number below the stated range.
By their numbers in this assay, from the lowest: compounds 4 and 2 (each within the scatter of the next); then compound 1; then compound 3.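

Trifluoromethyl in place of methoxy on this aromatic carbon gives a 7.1-fold lower number from compound 3 to compound 4 (0.85 log units; beyond the scatter) and so the choice of group here matters. Where the trifluoromethyl sits matters less clearly: 4-(trifluoromethyl)phenyl in place of 2-(trifluoromethyl)phenyl gives a 1.6-fold lower number from compound 2 to compound 4 (0.21 log units; within the scatter) and this cannot be told apart from repeat measurements. 4-(Trifluoromethyl)phenyl in place of 2-chlorophenyl gives a 3.4-fold lower number from compound 1 to compound 4 (0.53 log units; beyond the scatter) and this step changes both the group and its place on the ring.

As far as these compounds go, whether a nitrile or a carboxylic acid on this aromatic carbon would give a lower or higher number remains open. Nothing shown here explains the size of these steps.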